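Shortening the Nitrile Chain on a Tetrabrominated Core

The source may hold more compounds than are shown below. What is called first, only, known or untested is meant among the compounds shown, and "the series" means these compounds.

Compound 3 `N#CCCCCn1cnc2c(Br)c(Br)c(Br)c(Br)c21` carries a 4-cyanobutyl chain on the shared core. In a functional assay on MCF7 cells (Homo sapiens) for cytotoxicity, read by MTT assay, with a stated time of 24 h, tested at 50 uM (on this read-out higher numbers stand for a weaker effect at the one concentration tested and lower numbers for a stronger effect), compound 3 gives 18%. Compound 1 `N#CCCn1cnc2c(Br)c(Br)c(Br)c(Br)c21` gives 23%, and compound 2 `Cc1nc2c(Br)c(Br)c(Br)c(Br)c2n1CCCC#N`, which also carries a methyl group on the core, gives 5%. Compound 3 thus lies within the scatter of compound 1 and beyond the scatter from compound 2; among the three numbers it stands second highest.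

Compound 4 `N#CCCCn1cnc2c(Br)c(Br)c(Br)c(Br)c21` differs from compound 3 by cyano in place of cyanomethyl on a saturated chain carbon, three bonds along the chain from an aromatic nitrogen. Within the data shown here, the one measured step that bears on a change of this kind is a number 5 percentage points lower from compound 1 to compound 3 (within the scatter), which is within the scatter. Among the measured compounds shown here, compound 2 differs from compound 3 and from compound 4 in two places, so its number gives no step. Compound 4 is therefore expected to sit close to compound 3, with an expected step of a number 2 percentage points higher from compound 3 to compound 4 (within the scatter) that does not pass beyond the scatter. The estimate for compound 4 in this assay is 20%, within a range from 8% to 35%.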

Compound 4, a percentage reported as activity, at one concentration (the size of the read-out at that concentration, not a potency): 16%
Compound 4: middle estimate off by 4 percentage points, on the high side; the range from low to high includes it.
By their numbers in this assay, from the lowest: compound 2; then compounds 4, 3 and 1 (each within the scatter of the next).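

Among these compounds, with compound 4 the nitrile chain on the shared core is seen at three lengths, and in this assay the single steps along that series all lie within the scatter: a number 2 percentage points lower from compound 3 to compound 4 (within the scatter) and a number 7 percentage points lower from compound 1 to compound 4 (within the scatter). Compound 4 also gives compound 2 a partner that differs in one place only, and hydrogen in place of methyl on an aromatic carbon gives a number 11 percentage points higher from compound 2 to compound 4 (beyond the scatter), a modest step beyond the scatter. Among these compounds, then, the methyl group on the core marks a step beyond the scatter, while the chain steps do not. Nothing measured here accounts for these numbers.

From the compounds shown here alone, it remains open whether the methyl step recurs with the 2-cyanoethyl or 4-cyanobutyl chain. Also open, going by these compounds, is how the number would respond to an amine or a carboxylic acid in place of the nitrile, or to a longer chain.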